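The compounds below may be only part of what the source reports. "The series", "measured", "known", "first", "only" and "open" are said of these compounds alone.

Compound 1 `O=C(CSc1nncc2cncn12)c1ccccc1`: > 48000 nM
Compound 2 `CC(C)CCSc1nncc2cncn12`: 9000 nM

Both compounds share one core and differ only in the group attached through the sulfur. Going by the values given here, in a functional assay for inhibition, with Homo sapiens as the target (a higher number here means a weaker inhibitor, a lower number a stronger inhibitor), compound 2 gives 9000 nM, the only plain number among the two results. Compound 1 gives > 48000 nM, which is a limit of the assay rather than a number. That limit of > 48000 nM in this assay, at which 1 of the 2 values shown sits, is the one further result shown, so compound 2 stands alone as the single measured value.

Compound 3 `CCOC(=O)CSc1nncc2cncn12` has not been measured. It differs from compound 2 by ethoxycarbonyl in place of isobutyl on a saturated chain carbon bound to a sulfur. Among the compounds with values here, no step between measured compounds is given, so the size of this change has to be judged from the two results alone. Compound 1, whose chain also carries a carbonyl, reached only the limit (the limit of > 48000 nM in this assay, at which 1 of the 2 values shown sits). The chain of compound 3 likewise carries a carbonyl, and the step expected in this assay a 4.4-fold higher number from compound 2 to compound 3 (0.65 log units; beyond the scatter) points toward weaker inhibition, beyond the usual scatter. Compound 3 is therefore estimated at 40000 nM, in a range from 10000 nM to 150000 nM, with a fair chance that only a limit is returned.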

Compound 3, half-maximal inhibitory concentration: > 48000 nM
Compound 3: no number, only a limit; the forecaster's own chance of this, stated with the estimate: 55%; middle value at least 1.2-fold (0.07 log units) from the limit.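

In this assay, going by these compounds alone, putting ethoxycarbonyl in place of isobutyl on a saturated chain carbon bound to a sulfur gives an at least 5.3-fold higher number from compound 2 to compound 3 (0.72 log units; beyond the scatter), the first readable step at this position, and it runs toward weaker inhibition by more than the usual scatter. The step from compound 1 to compound 3, ethoxy in place of phenyl on a carbonyl carbon, cannot be read, as both ends are limits, so these two compounds cannot be ranked against each other. Among the three compounds, the two with a carbonyl in the chain both end at the limit and only compound 2, with its plain alkyl chain, gives a number, which makes the carbonyl-bearing chains look unfavourable here, though the readout at this end is capped: the limit of > 48000 nM in this assay, at which 2 of the 3 values shown sit.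

Within the data shown here, what stays open is whether anything at this position can improve on compound 2, at 9000 nM, since no step yet runs toward stronger inhibition. A longer alkyl chain, an amine or a carboxylic acid on the same carbon would test whether the loss belongs to the carbonyl itself or to any departure from isobutyl.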